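A Methyl on the Nitrogen of Compound 2

The compounds below may be only part of what the source reports. "The series", "measured", "known", "first", "only" and "open" are said of these compounds alone.

- Compound 1 (`COc1cc(/C=C/c2ccc3c(ccn3S(=O)(=O)c3ccccc3)c2)cc(OC)c1OC`) gives > 5000 nM (a limit of the assay, not a number)
- Compound 2 (`COc1cc(/C=C/c2ccc3[nH]ccc3c2)cc(OC)c1OC`) gives 470 nM

Within the data shown here, in a functional assay on A549 cells (Homo sapiens) for inhibition (a lower number here means a stronger inhibitor, a higher number a weaker inhibitor), compound 2 gives 470 nM, the only exact number so far. The value for compound 1 is only a limit, as the limit of > 5000 nM in this assay, at which 1 of the 2 values shown sits, records. Compound 3 (`COc1cc(/C=C/c2ccc3c(ccn3C)c2)cc(OC)c1OC`) has methyl in place of hydrogen on an aromatic nitrogen. Among the measured compounds shown here, one measured step concerns this same nitrogen, and it is large: an at least 10-fold lower number from compound 1 to compound 2 (1.02 log units; beyond the scatter). That step involves phenylsulfonyl, not methyl, so it shows that the group here can matter but gives no direct measure for methyl. The expected change is therefore small, with no clear direction and nothing beyond the scatter: the estimate is a 1.2-fold lower number from compound 2 to compound 3 (0.07 log units; within the scatter). For compound 3 the expected value is 400 nM, with an estimated range from 120 nM to 1500 nM.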

Compound 3, half-maximal inhibitory concentration: 470 nM
For compound 3 the middle estimate is 1.2-fold (0.07 log units) below the measured one, and the stated range covers the measured number.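

In this assay, putting methyl in place of the hydrogen on the aromatic nitrogen leaves the result in place: no change at the digits printed from compound 2 to compound 3 (within the scatter). The hydrogen on this nitrogen is therefore not required for the inhibition seen here, something the earlier pair could not show, as it offered no direct measure for methyl. Phenylsulfonyl now stands apart from both hydrogen and methyl, with an at least 10-fold lower number from compound 1 to compound 3 (1.02 log units; beyond the scatter), and the true size of this step stays open, as compound 1 is only a limit: the limit of > 5000 nM in this assay, at which 1 of the 3 values shown sits.

The compounds shown include nothing on this nitrogen between methyl and phenylsulfonyl. An ethyl group, a longer chain or an acetyl group there would help to tell whether the weaker result of compound 1 goes with the sulfonyl, the phenyl ring or neither.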